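This account rests on a few compounds, and the source may have more. Where it says the series, first, only, none or still open, it means among the compounds named here.

In an ADME assay on isolated protein for pharmacokinetics, with UDP-glucuronosyltransferase 1A9 (Homo sapiens) as the target, read by LC-MS, with a stated time of 60 min, at 37 degrees C, tested at 1 uM, in the presence of a further agent that is not named here (a higher number here means that the compound lasts longer, a lower number that the compound disappears faster), the compounds are followed over time to see how quickly they vanish. Compound 1 `NS(=O)(=O)CC(=O)NCCSc1nonc1/C(=N/O)Nc1cccc(Cl)c1` gives 0.9 h there, the lower of the two plain numbers recorded so far. Compound 2 `C[C@H](CSc1nonc1/C(=N/O)Nc1ccc(F)c(Br)c1)NC(=O)CS(N)(=O)=O` gives 1.33 h, which sits within the usual scatter of the value for compound 1, so no order between them can be claimed. Compound 3 `CC(C)(O)CC(=O)NCCSc1nonc1/C(=N/O)Nc1ccc(F)c(C(F)F)c1` reaches only > 3 h, which is a limit of the assay and not a number, the point noted as the limit of > 3 h in this assay, at which 1 of the 3 values shown sits.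

Compound 4 `N#Cc1cc(N/C(=N\O)c2nonc2SCCNC(=O)CS(N)(=O)=O)ccc1F` has not yet been measured. It differs from compound 1 in one place: 3-cyano-4-fluorophenyl in place of 3-chlorophenyl on an amine nitrogen, while the rest of the molecule stays the same. Within the data shown here, no step between two measured compounds covers this kind of change, so there is nothing measured to lean on. The step from compound 1 to compound 4 in this assay is expected to be small, a 1.3-fold higher number from compound 1 to compound 4 (0.12 log units; within the scatter), not clearly beyond the scatter. Compound 4 is therefore expected to give about 1.2 h, most likely between 0.6 h and 2.5 h.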

Compound 4, half-life: > 3 h
Compound 4 was reported as a limit; the forecaster's own chance of this, stated with the estimate: 10%; middle value at least 2.5-fold (0.39 log units) from the limit.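

Among these compounds, replacing 3-chlorophenyl with 3-cyano-4-fluorophenyl on the amine nitrogen, with the rest of the molecule unchanged, gives the first comparison in this assay of two compounds that differ in only one place. Among the compounds shown here, this change gives an at least 3.3-fold higher number from compound 1 to compound 4 (0.52 log units; beyond the scatter), so the group at this position can clearly affect how long the compound lasts, even though the earlier compounds offered no such comparison. Compound 4 gives > 3 h, which is a limit of the assay and not a number, so the step has a known floor but no known upper end: the limit of > 3 h in this assay, at which 2 of the 4 values shown sit.

The compounds shown do not separate the part played by the nitrile from that of the fluorine within the new group. They also leave open how a carboxylic acid or an amine on the same phenyl ring would behave.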